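Aryl ether swap and mouse liver microsome half-life

A few compounds are considered here, and "the series" means these few. Any claim that something is new, unique, unknown or untested is made for them only; others in the source may bear on it.

Compound 2 `C=CC(=O)NCc1coc(-c2c(N)ncnc2Nc2ccc(Oc3cc(Cl)ccc3Cl)c(Cl)c2)n1` carries a 2,5-dichlorophenyl on an oxygen on an aromatic ring. In an in vitro ADME assay on microsomes from liver (Mus musculus) for metabolic stability, tested at 5 uM (on this read-out higher numbers stand for a longer-lived compound and lower numbers for a shorter-lived compound), compound 2 gives 0.95 h, the higher of the two plain numbers in the set, while compound 1 `C=CC(=O)NCc1coc(-c2c(N)ncnc2Nc2ccc(OCc3ccccn3)c(F)c2)n1` gives 0.15 h, a gap beyond the scatter. Compound 3 `C=CC(=O)NCc1coc(-c2c(N)ncnc2Nc2ccc(Oc3cccc(F)c3)c(Cl)c2)n1` reaches only a limit of this assay at > 1.66 h (the limit of > 1.66 h in this assay, at which 1 of the 3 values shown sits). Within the data shown here, the single one-place step, an at least 1.7-fold higher number from compound 2 to compound 3 (0.24 log units; that floor lies within the scatter), is therefore a floor rather than a number. Compound 4 `C=CC(=O)NCc1coc(-c2c(N)ncnc2Nc2ccc(Oc3ccccn3)c(Cl)c2)n1` differs from compound 2 thus: pyridin-2-yl in place of 2,5-dichlorophenyl on an oxygen on an aromatic ring. Among the measured compounds shown here, compound 1 differs from compound 4 in two places and gives no step. Compound 4 is expected to sit near compound 2, at 1 h, from 0.4 h to 2.5 h. The expected step is a 1.1-fold higher number from compound 2 to compound 4 (0.02 log units; within the scatter), within the scatter.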

Compound 4, half-life: 0.25 h
The estimate for compound 4 lay 4.0-fold (0.60 log units) above the measured number, outside the stated range (below it).
By their numbers in this assay, from the lowest: compounds 1 and 4 (each within the scatter of the next); then compound 2. At a limit, above all of these: compound 3.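

Among these compounds, on an oxygen on an aromatic ring, the group can shift the half-life: pyridin-2-yl in place of 2,5-dichlorophenyl gives a 3.8-fold lower number from compound 2 to compound 4 (0.58 log units; beyond the scatter), the only step here with a plain number at both ends. Pyridin-2-yl in place of 3-fluorophenyl gives an at least 6.6-fold lower number from compound 3 to compound 4 (0.82 log units; beyond the scatter), which is a floor. Compound 3 stands at a limit, not a number: the limit of > 1.66 h in this assay, at which 1 of the 4 values shown sits.

Compound 2 and compound 4 differ in both the ring nitrogen and the two chlorines, so these two changes stay unseparated. An unsubstituted phenyl or a chloropyridinyl on the same oxygen would bear on this.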